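The source may report more compounds than this note shows. Statements on the series, on what has been measured and on what is new or still open speak of the compounds shown alone.

In an assay on isolated protein for inhibition of Myeloperoxidase (Homo sapiens) (on this read-out higher numbers stand for weaker inhibition and lower numbers for stronger inhibition), compound 1 `NCCCc1c[nH]c2ccc(F)cc12` gives 650 nM, while compound 2 `NCCCCc1c[nH]c2ccc(F)cc12` gives 12 nM. The two are separated by a 54-fold lower number from compound 1 to compound 2 (1.73 log units; beyond the scatter), so compound 2 holds the lower of the two numbers shown so far, with compound 1 its only neighbour. Compound 3 `NCCCCCCc1c[nH]c2ccc(F)cc12` has not yet been measured in this assay; it differs from compound 2 by 2-aminoethyl in place of amino on a saturated chain carbon, four bonds along the chain from an aromatic carbon, so the chain between the core and the terminal amine grows once more. Among the measured compounds shown here, the only measured step that bears on this kind of change is a 54-fold lower number from compound 1 to compound 2 (1.73 log units; beyond the scatter), where the chain was lengthened by a single carbon. Whether a further two carbons continue in the same direction, or overshoot, cannot be read from two compounds alone. The estimate for compound 3 therefore leans on compound 2 and on the size of a 54-fold lower number from compound 1 to compound 2 (1.73 log units; beyond the scatter), and expects a change of a 1.3-fold higher number from compound 2 to compound 3 (0.10 log units; within the scatter) in this assay. Compound 3 is accordingly expected to give about 15 nM, most likely between 3 nM and 80 nM.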

Compound 3, half-maximal inhibitory concentration: 580 nM
Estimate against measurement, compound 3: 39-fold (1.59 log units) below; the measured number lies above the stated range.
By their numbers in this assay, from the lowest: compound 2; then compounds 3 and 1 (each within the scatter of the next).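

In this assay, the gain from lengthening the chain does not continue: 2-aminoethyl in place of amino, on a saturated chain carbon, four bonds along the chain from an aromatic carbon, gives a 48-fold higher number from compound 2 to compound 3 (1.68 log units; beyond the scatter) and so cancels the earlier gain in a single step. The 3-aminopropyl change gives a 1.1-fold lower number from compound 1 to compound 3 (0.05 log units; within the scatter) and leaves the longest and shortest chains shown level with each other, so only compound 2 at 12 nM stands apart, and in these three compounds the response to chain length at this position rises and falls instead of running in one direction. Nothing available here accounts for this turn in the series.

The three compounds do not show how sharply the read-out turns, since a chain of intermediate length, one carbon longer than that of compound 2, would be needed to tell a narrow optimum from a broader one, and a still longer chain to show whether the trend continues. They also leave open whether the terminal amine is needed at all, or whether a hydroxyl or a carboxylic acid at the chain end would serve on the chain of compound 2.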